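The source may hold more compounds than are shown below. What is called first, only, known or untested is meant among the compounds shown, and "the series" means these compounds.

In an assay on HEK293 cells for inhibition of Lysophosphatidylserine lipase ABHD12 (Homo sapiens), read by scintillation counting, with stated times of 30 min and 5 min (on this read-out lower numbers stand for stronger inhibition and higher numbers for weaker inhibition), compound 2 `Cc1ccc(C(=O)NC2CCCCCC2)c(=O)n1Cc1ccc(F)cc1` gives > 10000 nM. That value is a limit of the assay rather than a number, so compound 2 stands at the edge of what this assay can report. Among the compounds with values here, compound 1 `Cc1c(Br)cc(C(=O)NC2CCNCC2)c(=O)n1Cc1ccc(F)cc1` is the only other compound measured. In this assay compound 1 gives > 10000 nM, again a limit. Within the data shown here, the two values therefore sit together at the limit of > 10000 nM in this assay, at which 2 of the 2 values shown sit, and no measured step between them can be drawn: the data show only that neither compound reached a number.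

Compound 3 `Cc1c(Cl)cc(C(=O)NC2CCCCCC2)c(=O)n1Cc1ccc(F)cc1` is not yet measured. It differs from compound 2 in one place, namely (chloro in place of hydrogen on an aromatic carbon). The chlorine is a single heavy atom added to the shared core, with the amide and the cycloheptyl group left untouched.

Without any measured step to rest on, the expected step of an at least 1.4-fold lower number from compound 2 to compound 3 (0.15 log units; that floor lies within the scatter) is small, pointing toward slightly stronger inhibition but barely beyond the usual scatter. Compound 3 is thus expected to give about 7000 nM, most likely between 1500 nM and 30000 nM.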

Compound 3, half-maximal inhibitory concentration: > 10000 nM
Compound 3: only a limit was reported (the forecaster's own chance of this, stated with the estimate: 55%); at least 1.4-fold (0.15 log units) between middle value and limit.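

Within the data shown here, compound 2 and compound 3 both stop at a limit rather than a number, so no step between them can be read in this assay: the limit of > 10000 nM in this assay, at which 3 of the 3 values shown sit. Left open is whether chloro in place of hydrogen changes inhibition at all, and how far beyond that limit compound 1, compound 2 and compound 3 each lie.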